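The source may report more compounds than this note shows. Statements on the series, on what has been measured and on what is new or still open speak of the compounds shown alone.

Measured so far in a functional assay on MDA-MB-231 cells (Homo sapiens) for antiproliferative activity, read by MTT assay, with a stated time of 48 h; a higher number here means a weaker inhibitor, a lower number a stronger inhibitor:

Compound 1 `C=CS(=O)(=O)N1CCN(c2ncnc3ccc(-c4ccccc4)cc23)CC1`: 47900 nM
Compound 2 `C=CS(=O)(=O)N1CCN(c2ncnc3sc(-c4ccc(C(F)(F)F)cc4)cc23)CC1`: 6410 nM

Two compounds are in hand. Going by the values given here, compound 2 stands at the lowest number of the two; the only other number, that of compound 1, sits well above it, and the gap between the two values is beyond the usual scatter of this assay. Among the compounds with values here, no pair differing in a single place has been measured, so no single-change step is known, and nothing can be said about what a change on the shared core of compound 2 does to the number.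

Compound 3 `C=CS(=O)(=O)N1CCN(c2ncnc3sc(-c4cn(C)nc4C(F)(F)F)cc23)CC1` is the next compound for this assay. It differs from compound 2 in one place: 1-methyl-3-(trifluoromethyl)-1H-pyrazol-4-yl in place of 4-(trifluoromethyl)phenyl on an aromatic carbon.

Within the data shown here, with no comparable step on record, the expectation rests on compound 2 alone. A change of this size on a group that is kept otherwise is expected to move the number modestly, if at all, and more likely toward a weaker inhibitor; the expected step is a 1.9-fold higher number from compound 2 to compound 3 (0.27 log units; within the scatter). Compound 3 is therefore estimated at 12000 nM, with a range from 4000 nM to 40000 nM.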

Compound 3, half-maximal inhibitory concentration: 10400 nM
Compound 3: middle estimate off by 1.2-fold (0.06 log units), on the high side; the measured number falls inside the stated range.
By their numbers in this assay, from the lowest: compounds 2 and 3 (each within the scatter of the next); then compound 1.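

In this assay, 1-methyl-3-(trifluoromethyl)-1H-pyrazol-4-yl in place of 4-(trifluoromethyl)phenyl on the aromatic carbon next to the ring sulfur gives a 1.6-fold higher number from compound 2 to compound 3 (0.21 log units; within the scatter), so this change does not separate the two compounds. Going by these compounds alone, this is the first single-place comparison, and it shows that a six-membered aromatic ring of carbon only and a five-membered aromatic ring with 2 hetero atoms can be exchanged here, with hydrogen-bond acceptors on the group going from 0 to 2 at 10 heavy atoms, without a step beyond the scatter. No measurement at hand explains this result.

As far as these compounds go, the pair keeps a trifluoromethyl group on both rings, so what that group contributes stays open, as does the effect of a morpholine, a carboxylic acid or a plain methyl on this aromatic carbon. Compound 1 differs from compound 2 and from compound 3 in more than one place, so its printed value cannot be assigned to any single change, and the contribution of the core remains unresolved.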